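A few compounds are considered here, and "the series" means these few. Any claim that something is new, unique, unknown or untested is made for them only; others in the source may bear on it.

Working notes on a small series of fused bicyclic chloro compounds bearing a chloromethyl-substituted benzyl group.

Compound 1 `Nc1nc(Cl)c2ncn(Cc3ccccc3CCl)c2n1` is the parent of the step considered here. In a functional assay on IGROV-1 cells (Homo sapiens) for cytotoxicity, read by sulforhodamine B assay, with a stated time of 48 h (on this read-out lower numbers stand for higher toxicity in this test and higher numbers for lower toxicity in this test), compound 1 gives > 100000 nM, and this is a limit of the assay rather than a number. Compound 1 therefore stands at the limit of > 100000 nM in this assay, at which 1 of the 2 values shown sits, so its exact position within the range cannot be placed. A second measured compound, compound 2 `ClCc1ccc(Cn2cnc3c(Cl)nc(Cl)nc32)cc1`, carries a chloro group where compound 1 carries the amino group and has the chloromethyl group on the other position of the benzyl ring; in this assay compound 2 gives 60300 nM. For the measured compounds named here, no step between these two measured compounds is counted, and their two values show only weak cytotoxicity in both cases.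

Compound 3 `ClCc1ccccc1Cn1cnc2c(Cl)ncnc21` is not yet measured. Its change from compound 1 is hydrogen in place of amino on an aromatic carbon. Given that compound 1 sits at the limit and compound 2 is also weak, the step from compound 1 to compound 3 is expected to be an at least 1.2-fold lower number from compound 1 to compound 3 (0.09 log units; that floor lies within the scatter), that is, nothing beyond the scatter in either direction. Compound 3 is estimated at 80000 nM, within 30000 nM to 200000 nM.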

Compound 3, concentration lethal to 50% of the cells: 55000 nM
Beside the measured number, compound 3's estimate is 1.5-fold (0.16 log units) above it, and the stated range covers the measured number.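

Replacing amino with hydrogen on the aromatic carbon between two ring nitrogen atoms gives, in this assay, an at least 1.8-fold lower number from compound 1 to compound 3 (0.25 log units; that floor lies within the scatter). That step can be read only as a floor because the entry for compound 1 is a limit of the assay and not a number: the limit of > 100000 nM in this assay, at which 1 of the 3 values shown sits. With hydrogen at this place the ortho-free parent pair now has one true number, yet compound 3 at 55000 nM still sits high on this read-out, so the change gives a readable value without showing strong toxicity in this test.

The compounds shown leave open how other groups on this aromatic carbon, such as a methyl, a methoxy or a dimethylamino group, would place in this assay, and how far the true value of compound 1 lies from that of compound 3. They also do not separate the place of the chloromethyl group on the benzyl ring from the group on this carbon, as compound 2 differs from the others in more than one place.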